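Butyl on the ring amine of a sulfonylindole

The compounds below may be only part of what the source reports. "The series", "measured", "known", "first", "only" and "open" are said of these compounds alone.

Measured compounds in an assay on HEK293 cells for displacement of a labelled ligand from 5-hydroxytryptamine receptor 6 (Homo sapiens), read by scintillation counting; on this read-out lower numbers stand for stronger inhibition and higher numbers for weaker inhibition:
compound 1 `COc1ccc2c(c1)c(C1=CCNCC1)cn2S(=O)(=O)c1cccc2ncccc12` gives 4 nM;
compound 2 `COc1ccc2c(c1)c(C1=CCNCC1)cn2S(=O)(=O)c1ccc2cccnc2c1` gives 2 nM;
compound 3 `COc1ccc2c(c1)c(C1=CCNCC1)cn2S(=O)(=O)c1cc2ccccc2cn1` gives 6 nM.

Compound 2 has the lowest number of the three. The step of a 2.0-fold lower number from compound 1 to compound 2 (0.30 log units; within the scatter) is within the scatter, so compound 1 and compound 2 cannot be told apart, whereas a 3.0-fold higher number from compound 2 to compound 3 (0.48 log units; beyond the scatter) is a modest, real difference. Compound 4 `CCCCN1CC=C(c2cn(S(=O)(=O)c3ccc4cccnc4c3)c3ccc(OC)cc23)CC1` differs from compound 2 by butyl in place of hydrogen on an amine nitrogen in a ring. None of the measured steps touches this ring amine; all of them swap the group on the sulfonyl sulfur, so no shown step bears on this change, and its size and direction cannot be read from the data. A modest weakening is expected, a 4.0-fold higher number from compound 2 to compound 4 (0.60 log units; beyond the scatter), with wide uncertainty. Compound 4 is therefore estimated at 8 nM, plausibly between 2 nM and 40 nM.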

Compound 4, inhibition constant: 219 nM
For compound 4 the middle estimate is 27-fold (1.44 log units) below the measured one; measured number outside the range, above it.
By their numbers in this assay, from the lowest: compounds 2, 1 and 3 (each within the scatter of the next, the first and the last beyond it); then compound 4.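

In this assay, butyl in place of hydrogen on the ring amine gives a 110-fold higher number from compound 2 to compound 4 (2.04 log units; beyond the scatter), a larger step than any swap of the group on the sulfonyl sulfur among compound 1, compound 2 and compound 3. Going by these compounds alone, the ring amine is therefore far more sensitive to this change than the earlier steps could reveal. Nothing available explains the size of this step.

This single pair leaves open whether smaller groups such as methyl or ethyl would cost as much as butyl. It also leaves open whether butyl would have the same effect alongside quinolin-5-yl or isoquinolin-3-yl on the sulfonyl sulfur.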